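Closing the Diethylamino Chain into a Piperidine Ring

The compounds below may be only part of what the source reports. "The series", "measured", "known", "first", "only" and "open" are said of these compounds alone.

Three measured compounds share one core and differ in the side chain on its nitrogen. Compound 1 `O=c1oc2cccnc2n1CN1CCN(c2cccc(C(F)(F)F)c2)CC1` gives 3.6 mg/kg in a functional assay on the whole organism with Mus musculus as the target; on this read-out higher numbers stand for an effect only at larger amounts of compound and lower numbers for an effect already at smaller amounts. For compound 2 `Cc1ccc2oc(=O)n(CCN3CCN(c4ccccc4)CC3)c2n1` the result in this assay is only a limit of the test, > 50 mg/kg, not a number. Going by these compounds, compound 3 `CCN(CC)CCn1c(=O)oc2cccnc21` likewise reaches only a limit in this assay, > 25 mg/kg, so its true value is unknown. It stands among the compounds that show no effect up to the highest amount given, where one of the three results sits (the limit of > 25 mg/kg in this assay, at which 1 of the 3 values shown sits), and the other limit of > 50 mg/kg in this assay, at which 1 of the 3 values shown sits, belongs to a second one.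

Compound 4 `O=c1oc2cccnc2n1CCN1CCCCC1` has not yet been measured. It differs from compound 3 by piperidin-1-yl in place of diethylamino on a saturated chain carbon, two bonds along the chain from an aromatic nitrogen. Going by the values given here, no step between two measured compounds is available, so the size of this change cannot be read from the data. The step that the limit leaves unreadable from compound 3 to compound 4 is expected to be small, within the usual scatter. Compound 4 is therefore expected to give about 30 mg/kg, most likely between 10 mg/kg and 100 mg/kg, with a fair chance that only a limit is reported again.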

Compound 4, dose for half-maximal effect: > 25 mg/kg
Compound 4: no number, only a limit; the forecaster's own chance of this, stated with the estimate: 60%; the middle value is on the limit's open side.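

Compound 3 and compound 4 each give only a limit of the test in this assay, and the step between them cannot be read. The compounds shown leave open whether piperidin-1-yl in place of diethylamino changes the true value at all.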